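The source may report more compounds than this note shows. Statements on the series, on what has been measured and on what is new or still open speak of the compounds shown alone.

Measured so far in an assay on isolated protein for displacement of a labelled ligand from 5-hydroxytryptamine receptor 6 (Homo sapiens), read by scintillation counting, with a stated time of 1 h; a lower number here means a stronger inhibitor, a higher number a weaker inhibitor:
compound 1 `O=S(=O)(c1ccccc1)n1ccc2c(O)cccc21` gives 108 nM
compound 2 `COc1ccc2c(ccn2S(=O)(=O)c2ccccc2)c1` gives 127 nM
compound 3 `CN(C)c1cccc2c1ccn2S(C)(=O)=O` gives 4720 nM

Compound 3 stands at the highest of the three numbers in this assay, and its gaps to compound 1 and to compound 2 both lie beyond the usual scatter, so compound 3 is the weakest binder here. Compound 4 `CN(C)c1cccc2c1ccn2S(=O)(=O)N1CCCCC1` differs from compound 3 in one place: piperidin-1-yl in place of methyl on a sulfonyl sulfur. For the measured compounds named here, no measured pair shows this change on its own; compound 1 and compound 2 carry a different group on the sulfonyl sulfur but also differ elsewhere, so their numbers cannot be read as this step. A moderate move toward a lower number is expected, so the step from compound 3 to compound 4 is estimated at a 3.1-fold lower number from compound 3 to compound 4 (0.50 log units; beyond the scatter). Compound 4 is expected to give 1500 nM, with a range from 400 nM to 6000 nM.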

Compound 4, inhibition constant: 39100 nM
Compound 4: middle estimate off by 26-fold (1.42 log units), on the low side; the measured number lies above the stated range.
By their numbers in this assay, from the lowest: compounds 1 and 2 (each within the scatter of the next); then compound 3; then compound 4.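

In this assay, the sulfonyl sulfur proves sensitive to what it carries: piperidin-1-yl in place of methyl gives an 8.3-fold higher number from compound 3 to compound 4 (0.92 log units; beyond the scatter), so on this core the change weakens binding. Nothing available explains why the step goes this way.

On these data alone, it remains open where an ethyl chain or a morpholin-4-yl ring on the sulfonyl sulfur would fall relative to compound 3 and compound 4. Such groups could show whether the loss follows group size or is particular to piperidin-1-yl.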